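The compounds below may be only part of what the source reports. "The series", "measured", "known", "first", "only" and "open" are said of these compounds alone.

Measured so far:
- compound 1 `CN1CCN(CCCCCn2c3c(c4ccccc42)C(=O)c2c[n+]([O-])c4ccccc4c2C3=O)CC1` — 830 nM
- compound 2 `O=C1c2c[n+]([O-])c3ccccc3c2C(=O)c2c1c1ccccc1n2Cc1cn(C[C@@H](O)CO)nn1` — a limit, > 500 nM
- compound 3 `O=C1c2c[n+]([O-])c3ccccc3c2C(=O)c2c1c1ccccc1n2CCCCN1CCCCC1` — 230 nM

In a functional assay on SH-SY5Y cells (Homo sapiens) for cytotoxicity, read by MTT assay, with a stated time of 72 h (on this read-out higher numbers stand for weaker inhibition and lower numbers for stronger inhibition), compound 1 gives 830 nM and compound 3 gives 230 nM, the step of a 3.6-fold lower number from compound 1 to compound 3 (0.56 log units; beyond the scatter). Compound 2 reaches only a limit in this assay, > 500 nM, with no number behind it. The step that the limit leaves unreadable from compound 1 to compound 2 cannot be sized because of the limit of > 500 nM in this assay, at which 1 of the 3 values shown sits, whereas an at least 2.1-fold lower number from compound 2 to compound 3 (0.33 log units; beyond the scatter) is readable as a lower bound. Compound 2 thus stands at the weak end of the three, its place known only as a limit.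

Compound 4 `O=C1c2c[n+]([O-])c3ccccc3c2C(=O)c2c1c1ccccc1n2Cc1cn([C@@H]2O[C@H](CO)[C@@H](O)[C@H](O)[C@H]2O)nn1` differs from compound 2 by 3,4,5-trihydroxy-6-(hydroxymethyl)oxan-2-yl in place of 2,3-dihydroxypropyl on an aromatic nitrogen. None of the three measured steps touches this part of the molecule: each of them alters the chain on the aromatic nitrogen of the shared core, and the triazole substituent of compound 2 is itself present only in that one compound. Among the measured compounds shown here, no measured step therefore bears on the change, and the starting point, compound 2, is a limit rather than a number. With the closest analogue, compound 2, at > 500 nM, compound 4 is expected to stay near the limit as well, the change a step that the limit leaves unreadable from compound 2 to compound 4 being an estimate only. Compound 4 is expected at 1500 nM, in the range 500 nM to 6000 nM.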

Compound 4, half-maximal inhibitory concentration: 880 nM
Beside the measured number, compound 4's estimate is 1.7-fold (0.23 log units) above it, within the range that was stated.
By their numbers in this assay, from the lowest: compound 3; then compounds 1 and 4 (each within the scatter of the next).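

No step can be read from compound 2 to compound 4 in this assay, because compound 2 carries only a limit: the limit of > 500 nM in this assay, at which 1 of the 4 values shown sits.

The compounds shown leave open how 3,4,5-trihydroxy-6-(hydroxymethyl)oxan-2-yl and 2,3-dihydroxypropyl compare on this aromatic nitrogen, since only one of the two has a number behind it.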